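This account rests on a few compounds, and the source may have more. Where it says the series, first, only, none or still open, it means among the compounds named here.

Measured in a functional assay on MCF7 cells (Homo sapiens) for cytotoxicity, read by MTT assay, with a stated time of 72 h; a higher number here means a weaker inhibitor, a lower number a stronger inhibitor:
- compound 1 `COc1ccc(/C=C2\S/C(=N\c3csc(-c4ccc(Cl)cc4)c3)NC2=O)cc1`: 1000 nM
- compound 2 `O=C1N/C(=N/c2csc(-c3ccc(Cl)cc3)c2)S/C1=C\c1ccccn1`: 30200 nM

Compound 2 stands with the highest number of the two, its nearest neighbour being compound 1, which gives the lower value. For the measured compounds named here, the single measured step is a 30-fold higher number from compound 1 to compound 2 (1.48 log units; beyond the scatter). Compound 3 `COc1ccc(/C=C2\S/C(=N\c3csc(-c4ccc(Cl)cc4)c3)NC2=O)cc1OC` differs from compound 2 by 3,4-dimethoxyphenyl in place of pyridin-2-yl on a double-bonded chain carbon bound to a double-bonded ring carbon. This change reverses the direction of that step, moving from pyridin-2-yl back to a methoxy-bearing phenyl, so a large step towards a lower number is expected, roughly a 20-fold lower number from compound 2 to compound 3 (1.30 log units; beyond the scatter). Compound 3 is therefore estimated at 1500 nM, with a range from 400 nM to 6000 nM.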

Compound 3, half-maximal inhibitory concentration: 7600 nM
For compound 3 the middle estimate is 5.1-fold (0.70 log units) below the measured one; measured number outside the range, above it.
By their numbers in this assay, from the lowest: compound 1; then compound 3; then compound 2.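

In this assay a methoxy-bearing phenyl at this place does not by itself return the number to that of compound 1: 3,4-dimethoxyphenyl in place of pyridin-2-yl gives a 4.0-fold lower number from compound 2 to compound 3 (0.60 log units; beyond the scatter) and recovers only part of the loss. Methoxy in place of hydrogen on an aromatic carbon gives a 7.6-fold higher number from compound 1 to compound 3 (0.88 log units; beyond the scatter), so across these compounds a second methoxy does not go with a lower number. No measurement at hand offers a reason for either step.

Still open, as far as these compounds go, is how an unsubstituted phenyl, or a phenyl carrying a hydroxyl or a dimethylamino group, would read at this place.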